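Moving a methoxy group on a cinnamic acid triazole

The compounds below may be only part of what the source reports. "The series", "measured", "known", "first", "only" and "open" are said of these compounds alone.

Within the data shown here, compound 1 `COc1ccccc1-n1cc(COc2c(/C=C\C(=O)O)ccc(OC)c2CC=C(C)C)nn1` is the only member of this small set with a number. In a functional assay on HCT-116 cells (Homo sapiens) for cytotoxicity, read by MTT assay, with a stated time of 24 h (on this read-out higher numbers stand for weaker inhibition and lower numbers for stronger inhibition), compound 1 gives 32200 nM, so it is a weak inhibitor. Compound 2 `COc1ccc(/C=C\C(=O)O)c(OCc2cn(-c3ccccc3F)nn2)c1CC=C(C)C` carries a fluorophenyl on the same ring nitrogen, but in this assay compound 2 gives "not determined" (no result reported), so no number is available for it. Compound 3 `COc1ccc(-n2cc(COc3c(/C=C\C(=O)O)ccc(OC)c3CC=C(C)C)nn2)cc1` differs from compound 1 by 4-methoxyphenyl in place of 2-methoxyphenyl on an aromatic nitrogen. Among the measured compounds shown here, with no comparable step among measured compounds, the change from compound 1 to compound 3 is expected to stay within the usual scatter, as a 1.1-fold lower number from compound 1 to compound 3 (0.03 log units; within the scatter). Compound 3 is therefore estimated at 30000 nM, between 10000 nM and 90000 nM.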

Compound 3, half-maximal inhibitory concentration: 8700 nM
Compound 3: middle estimate off by 3.4-fold (0.54 log units), on the high side; the measured number lies below the stated range.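

In this assay, 4-methoxyphenyl in place of 2-methoxyphenyl on the aromatic nitrogen gives a 3.7-fold lower number from compound 1 to compound 3 (0.57 log units; beyond the scatter) and so stronger inhibition, though the step is modest. Among these compounds, this is the first sign that where the methoxy group sits on this phenyl ring can change the read-out, even with no atom gained or lost. No available measurement explains this difference.

Still open, from the compounds shown here alone, is how an amine or a longer chain in place of the methoxy group would read. Compound 2 has no number, so it cannot show how the fluorophenyl compares.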